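The compounds below may be only part of what the source reports. "The series", "measured", "known", "first", "only" and "open" are said of these compounds alone.

Working notes on the series. Of the compounds shown here, two have been measured in a functional assay on DLD-1 cells (Homo sapiens) for cytotoxicity, read by MTT assay, with a stated time of 48 h (on this read-out higher numbers stand for weaker inhibition and lower numbers for stronger inhibition), so far. Compound 1 `CCCCCCOc1ccc2c(Cl)ccnc2c1` gives 2660 nM. Compound 2 `C=CCOc1ccc2c(NCCN(C)C)ccnc2c1` gives 1530 nM, and the two numbers lie within the scatter of each other, so no order between them is claimed. Compound 3 `C=CCOc1ccc2c(Cl)ccnc2c1` is the next compound: its change from compound 2 is chloro in place of (2-(dimethylamino)ethyl)amino on an aromatic carbon. Within the data shown here, no comparable step has been measured. The step of a 1.6-fold higher number from compound 2 to compound 3 (0.21 log units; within the scatter) is expected to be small, towards a somewhat higher number, because compound 1 carries chloro at the same place and gives 2660 nM. Compound 3 is therefore estimated at 2500 nM, with a range from 900 nM to 7000 nM.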

Compound 3, half-maximal inhibitory concentration: 2890 nM
For compound 3 the middle estimate is 1.2-fold (0.06 log units) below the measured one, within the range that was stated.
By their numbers in this assay, from the lowest: compounds 2, 1 and 3 (each within the scatter of the next).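

In this assay, chloro in place of (2-(dimethylamino)ethyl)amino on the aromatic carbon opposite the ring nitrogen gives a 1.9-fold higher number from compound 2 to compound 3 (0.28 log units; within the scatter), so the much smaller group leaves the number within the scatter. With chloro held constant, vinyl in place of pentyl on the oxygen-bound chain gives a 1.1-fold higher number from compound 1 to compound 3 (0.04 log units; within the scatter), so neither change in these compounds separates from the scatter. No measurement here bears on a cause for either step.

From the compounds shown here alone, whether a primary amine or a carboxylic acid opposite the ring nitrogen would move the number beyond the scatter remains open. So does the effect of (2-(dimethylamino)ethyl)amino on the core of compound 1, which carries the longer chain.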